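Hydroxymethyl on a second core: an expected lipophilicity

This account rests on a few compounds, and the source may have more. Where it says the series, first, only, none or still open, it means among the compounds named here.

Compound 1, `COc1ccc(O)c(CSc2ccccc2)c1`: in a physicochemical assay for lipophilicity (on this read-out lower numbers stand for lower lipophilicity and higher numbers for higher lipophilicity), compound 1 gives 3.9
Compound 2, `COc1ccc(O)c(CSc2ccccc2CO)c1`: compound 2 gives 2.9
Compound 3, `Oc1cc2c(cc1CNc1ccccc1)OCC2`: compound 3 gives 2.9

Compound 2 differs from compound 1 by hydroxymethyl in place of hydrogen on an aromatic carbon, and that change produced a number 1.00 log units lower from compound 1 to compound 2 (beyond the scatter). Compound 3 is built on a different core; the difference between its core and the core of compound 1 is not broken down here. Compound 2 and compound 3 read the same at the digits given, and both stand below compound 1 by a margin beyond the scatter.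

Compound 4, `OCc1ccccc1NCc1cc2c(cc1O)CCO2`, carries the same change on the core of compound 3: hydroxymethyl in place of hydrogen on an aromatic carbon. The surroundings of the place are described in the same words in both cases, so the account treats this as the same change rather than merely the same kind. For the measured compounds named here, the step in this assay is expected to be a number 1.00 log units lower from compound 3 to compound 4 (beyond the scatter) because of a number 1.00 log units lower from compound 1 to compound 2 (beyond the scatter), which is the only measured instance of this change. Compound 4 is therefore estimated at 1.9, with a range from 1.4 to 2.4.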

Compound 4, partition coefficient: 1.9
Estimate against measurement, compound 4: no gap at the digits printed; measured number inside the range.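

In this assay hydroxymethyl in place of hydrogen on an aromatic carbon gave a number 1.00 log units lower from compound 3 to compound 4 (beyond the scatter) on the core of compound 3, and this matches in size a number 1.00 log units lower from compound 1 to compound 2 (beyond the scatter) on the core of compound 1, so within this series the change carried from one core to the other with its size intact. The agreement rests on a single pair on each of the two cores, so it describes these four compounds and sets no rule for any further core, nor for the same change where its surroundings differ. The account holds no evidence that bears on why the two steps agree.

The compounds shown leave open whether an amine such as aminomethyl, a carboxylic acid or a longer chain such as hydroxyethyl, entering in place of the same hydrogen, would also give matching steps on the two cores. They also leave open whether hydroxymethyl itself would give a step of this size on a third core.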